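Series notes: hydrogen in place of methyl, compound 2 to compound 3

The source may hold more compounds than are shown below. What is called first, only, known or untested is meant among the compounds shown, and "the series" means these compounds.

Measured so far:
compound 1, `CC(C)n1ncc2c(C(=O)NCc3ccccc3)cccc21`: > 40000 nM
compound 2, `Cc1ccc(-n2cc(CNC(=O)c3cccc4c3cnn4C(C)C)nn2)c(C)c1`: > 40000 nM

Both values come from a functional assay on HepG2 cells (Homo sapiens) for inhibition, read by MTT assay, with a stated time of 72 h; on this read-out higher numbers stand for weaker inhibition and lower numbers for stronger inhibition. For compound 1 the value > 40000 nM is a limit of the assay and not a number. For compound 2 the value > 40000 nM is likewise a limit and not a number. Among the compounds with values here, compound 2 therefore stands at the limit of > 40000 nM in this assay, at which 2 of the 2 values shown sit; nothing in these two values separates it from compound 1, and no step between measured compounds is available for the series.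

Compound 3, `Cc1ccccc1-n1cc(CNC(=O)c2cccc3c2cnn3C(C)C)nn1`, is not yet measured. It differs from compound 2 by hydrogen in place of methyl on an aromatic carbon. That is the whole of the change: 2,4-dimethylphenyl becomes 2-methylphenyl, with no other part of the structure touched.

With the only neighbouring point sitting at the limit, no ground exists for expecting a shift in either direction. For compound 3 the expected step is a step that the limit leaves unreadable from compound 2 to compound 3, none beyond the usual scatter, and most likely compound 3 again reports only a limit in this assay. The estimate for compound 3 is 60000 nM, within 20000 nM to 200000 nM.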

Compound 3, half-maximal inhibitory concentration: > 40000 nM
Compound 3: a limit, no number; the forecaster's own chance of this, stated with the estimate: 85%; the middle value does not contradict the limit.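

In this assay compound 3 gives > 40000 nM, which is a limit of the assay and not a number. Compound 2 likewise reports only a limit, so no step can be read between compound 2 and compound 3. The series stands as follows: the limit of > 40000 nM in this assay, at which 3 of the 3 values shown sit.

The compounds shown leave open what hydrogen in place of methyl does to inhibition in this assay.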